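From 3-ethynylphenyl to 3,4-dichlorophenyl: expectations for compound 4

The compounds below may be only part of what the source reports. "The series", "measured", "known", "first", "only" and "open" are said of these compounds alone.

In a functional assay on PC-3 cells (Homo sapiens) for antiproliferative activity, read by MTT assay, with a stated time of 48 h (a higher number here means a weaker inhibitor, a lower number a stronger inhibitor), compound 1 (`C#Cc1cccc(Nc2ncnc3cc(NC(=O)/C=C/c4ccccc4)sc23)c1`) gives 700 nM. Compound 2 (`COc1ccc(/C=C/C(=O)Nc2cc3c(Nc4ccc(Cl)c(Cl)c4)ncnc3s2)cc1`) gives 790 nM and compound 3 (`C#Cc1cccc(Nc2ncnc3sc(NC(=O)/C=C/c4ccccc4)cc23)c1`) gives 400 nM, which places compound 1 within the scatter of both.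

Compound 4 (`O=C(/C=C/c1ccccc1)Nc1cc2ncnc(Nc3ccc(Cl)c(Cl)c3)c2s1`) is still unmeasured. Relative to compound 1, it has 3,4-dichlorophenyl in place of 3-ethynylphenyl on a nitrogen on an aromatic ring. For the measured compounds named here, no measured pair isolates this change. Compound 2 also bears 3,4-dichlorophenyl and gives 790 nM, within the scatter of compound 1, so no step beyond the scatter is expected in this assay.

For compound 4 the estimate is 750 nM, with an expected range from 300 nM to 1900 nM. The estimated step is a 1.1-fold higher number from compound 1 to compound 4 (0.03 log units; within the scatter).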

Compound 4, half-maximal inhibitory concentration: 260 nM
Compound 4: the middle estimate sits 2.9-fold (0.46 log units) above what was measured; the measured number lies below the stated range.
By their numbers in this assay, from the lowest: compounds 4, 3, 1 and 2 (each within the scatter of the next, the first and the last beyond it).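

On the core of compound 1, the group on a nitrogen on an aromatic ring does affect the read-out: in this assay, 3,4-dichlorophenyl in place of 3-ethynylphenyl gives a 2.7-fold lower number from compound 1 to compound 4 (0.43 log units; beyond the scatter). This is the only single-place step among the compounds shown, and it lies beyond the scatter. No measurement available here accounts for it.

From the compounds shown here alone, whether the same change carries over to the core of compound 3 remains open. Also open, going by these compounds, is how a single chlorine, as in 3-chlorophenyl, or a morpholine on the phenyl ring would compare.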